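A few compounds are considered here, and "the series" means these few. Any claim that something is new, unique, unknown or untested is made for them only; others in the source may bear on it.

All the compounds here belong to one series, tested in a functional assay on the whole organism with Rattus norvegicus as the target; on this read-out lower numbers stand for an effect already at smaller amounts and higher numbers for an effect only at larger amounts of compound. For compound 1 `CCNS(=O)(=O)c1ccc(OC)c(C(=O)NCCN(C)Cc2ccccc2)c1` the result is only a limit of the assay, > 30 mg/kg, and not a number. Compound 2 `COc1cc(N(C)C)c(Cl)cc1C(=O)NC1CCN(Cc2ccccc2)C1` gives 0.12 mg/kg and compound 3 `CCNc1cc(OC)c(C(=O)NC2CCN(Cc3ccccc3)C2)cc1Cl` gives 0.1 mg/kg as measured values. These two numbers lie within the scatter of each other, so compound 3 stands level with compound 2.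

Compound 4 `COc1cc(N2CCCC2)c(Cl)cc1C(=O)NC1CCN(Cc2ccccc2)C1` has not been measured yet. It differs from compound 3 in one place, on the aromatic carbon ortho to a chloro group, where pyrrolidin-1-yl takes the place of ethylamino: pyrrolidin-1-yl in place of ethylamino on an aromatic carbon. A five-membered non-aromatic ring thus enters, and the hydrogen-bond donor of ethylamino leaves.

Going by the values given here, one measured step bears on this position: a 1.2-fold lower number from compound 2 to compound 3 (0.08 log units; within the scatter), a swap of dimethylamino for ethylamino that stayed within the scatter. The estimated step is a 1.5-fold higher number from compound 3 to compound 4 (0.18 log units; within the scatter), so no shift beyond the scatter is expected. That single step involved no ring, so the range is kept wide. For compound 4 the expected value is 0.15 mg/kg, within an estimated range from 0.04 mg/kg to 0.6 mg/kg.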

Compound 4, dose for half-maximal effect: 0.6 mg/kg
The estimate for compound 4 lay 4.0-fold (0.60 log units) below the measured number, and the stated range covers the measured number.
By their numbers in this assay, from the lowest: compounds 3 and 2 (each within the scatter of the next); then compound 4. At a limit, above all of these: compound 1.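

At this position, ortho to a chloro group, the earlier swap between two open-chain amino groups stayed within the scatter, so the position could have seemed indifferent to the exact amine. The ring changes that picture: in this assay there is a 6.0-fold higher number from compound 3 to compound 4 (0.78 log units; beyond the scatter), and the comparison with the dimethylamino compound gives a 5.0-fold higher number from compound 2 to compound 4 (0.70 log units; beyond the scatter), so both steps show that a larger dose is needed once pyrrolidin-1-yl sits here. Nothing measured here explains why this ring gives the higher number.

The compounds shown leave open whether any ring on this carbon gives the same result, or whether a smaller or larger one, such as azetidinyl or piperidinyl, behaves differently. They also leave open how a plain amino group or a longer chain on the nitrogen, such as propylamino, would compare.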